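This account rests on a few compounds, and the source may have more. Where it says the series, first, only, none or still open, it means among the compounds named here.

Working notes on the series. Compound 1 `Cc1ccc(/C=C(/SCc2ccc(Cl)cc2Cl)C(=O)c2ccc(Cl)cc2)s1` and compound 2 `Cc1ccc(CS/C(=C/c2ccc(C)s2)C(=O)c2ccc(Cl)cc2)cc1` share one core. In a functional assay on DU-145 cells (Homo sapiens) for inhibition, read by trypan blue exclusion, with a stated time of 96 h (a lower number here means a stronger inhibitor of growth, a higher number a weaker inhibitor of growth), compound 1 gives 50000 nM, and compound 2 gives 50000 nM. The change between them, (2,4-dichlorophenyl in place of 4-methylphenyl on a saturated chain carbon bound to a sulfur), produced no change at the digits printed from compound 2 to compound 1 (within the scatter). Compound 3 `Cc1ccc(CS/C(=C/c2ccc(Cl)c([N+](=O)[O-])c2)C(=O)c2ccc(C(=O)O)cc2)cc1` is built on a different core; the difference between the core of compound 2 and the core of compound 3 is not broken down here. In this assay compound 3 gives 1000 nM, the lowest of the three numbers, separated from compound 1 and from compound 2 by gaps beyond the scatter. Compound 4 `O=C(O)c1ccc(C(=O)/C(=C\c2ccc(Cl)c([N+](=O)[O-])c2)SCc2ccc(Cl)cc2Cl)cc1` has not yet been measured. It differs from compound 3 by 2,4-dichlorophenyl in place of 4-methylphenyl on a saturated chain carbon bound to a sulfur, the same change as that from compound 2 to compound 1, at the same place. Because the earlier pair measured no change at the digits printed from compound 2 to compound 1 (within the scatter), the expected step is no change at the digits printed from compound 3 to compound 4 (within the scatter) in this assay. This rests on a single prior pair on another core, so the expectation is thin. Compound 4 is accordingly estimated at 1000 nM in this assay, with a range from 400 nM to 2500 nM.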

Compound 4, concentration for 50% growth inhibition: 1000 nM
Compound 4: the middle estimate sits on the measured number at the digits printed; the range from low to high includes it.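

In this assay, 2,4-dichlorophenyl in place of 4-methylphenyl on a saturated chain carbon bound to a sulfur gave no change at the digits printed from compound 3 to compound 4 (within the scatter), and the step on the earlier core reads the same: the same change on two cores in this assay, no change at the digits printed (within the scatter) from compound 2 to compound 1 and no change at the digits printed (within the scatter) from compound 3 to compound 4, 1.0-fold (0.00 log units) apart, within the scatter of two such steps. Within this series, the change therefore carries from one core to the other without a step beyond the scatter, on the core of compound 3 as on the core of compound 2. This rests on two pairs and one change in one assay; it does not show that the change would read the same on a further core, that other groups at this place would be tolerated, or what separates the two cores.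

The compounds shown leave open whether a single-chlorine group such as 4-chlorophenyl, or a group of another kind such as an amine or a longer chain, would also leave the number unchanged at this place. They also leave open whether any replacement there gives a step beyond the scatter.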